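The compounds below may be only part of what the source reports. "The series", "measured", "known", "first", "only" and "open" are said of these compounds alone.

Measured so far in an ADME assay on L02 cells (Homo sapiens) for cytotoxicity, read by MTT assay, with a stated time of 24 h; on this read-out higher numbers stand for weaker inhibition and lower numbers for stronger inhibition:

compound 1, `COc1cc(/C=C2\CN(S(=O)(=O)c3ccc(F)cc3)C/C(=C\c3cc(OC)c(OC)c(OC)c3)C2=O)cc(OC)c1OC`, gives 12100 nM
compound 2, `COc1cc(/C=C2\CN(S(=O)(=O)c3ccc(NC(C)=O)cc3)C/C(=C\c3cc(OC)c(OC)c(OC)c3)C2=O)cc(OC)c1OC`, gives 13600 nM
compound 3, `O=C1/C(=C/c2cccc([N+](=O)[O-])c2)CN(S(=O)(=O)c2ccc(F)cc2)C/C1=C\c1ccccc1F`, gives 17000 nM

Compound 1 and compound 2 share one core and differ only in acetamido in place of fluoro on an aromatic carbon. That change made a step of a 1.1-fold higher number from compound 1 to compound 2 (0.05 log units; within the scatter), so on this read-out the two compounds are not distinguishable.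

Compound 3 is built on a different core; the difference between the two cores is not broken down here. Its value and those of compound 1 and compound 2 lie within the usual scatter of one another, so no order among the three can be read from these numbers.

Compound 4, `CC(=O)Nc1ccc(S(=O)(=O)N2C/C(=C\c3cccc([N+](=O)[O-])c3)C(=O)/C(=C/c3ccccc3F)C2)cc1`, is not yet measured. Within the data shown here, it differs from compound 3 by acetamido in place of fluoro on an aromatic carbon, the same change, at the same kind of place, as the one that turned compound 1 into compound 2. Since that earlier step was a 1.1-fold higher number from compound 1 to compound 2 (0.05 log units; within the scatter), the step from compound 3 to compound 4 is expected to be similarly small, about a 1.1-fold higher number from compound 3 to compound 4 (0.04 log units; within the scatter). On that basis compound 4 is estimated at 18700 nM, with a likely range from 9000 nM to 38000 nM, before any measurement is known.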

Compound 4, half-maximal inhibitory concentration: 18400 nM
Compound 4: middle estimate off by 1.0-fold (0.01 log units), on the high side; the range from low to high includes it.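

Putting acetamido in place of fluoro on the second core gave a step in this assay of a 1.1-fold higher number from compound 3 to compound 4 (0.03 log units; within the scatter), so this pair, like the first, cannot be told apart. Set side by side, the same change gives matching results on the two cores: the same change on two cores in this assay, a 1.1-fold higher number (0.05 log units; within the scatter) from compound 1 to compound 2 and a 1.1-fold higher number (0.03 log units; within the scatter) from compound 3 to compound 4, 1.0-fold (0.02 log units) apart, within the scatter of two such steps

This shows that, in these two pairs, swapping fluoro for acetamido left the number within the usual scatter, so the small step seen on the first core carried over to the second. It does not show that the change would stay this small on a third core, and it gives no reason why the two cores agree.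

Only fluoro and acetamido appear at this place in the compounds shown, so it remains open whether any other group there would shift the number beyond the scatter. An amine, a carboxylic acid or a longer chain on the amide would each put that question to the test.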